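A few compounds are considered here, and "the series" means these few. Any claim that something is new, unique, unknown or untested is made for them only; others in the source may bear on it.

The three measured compounds share one core and differ only in the group attached to a nitrogen on an aromatic ring. Compound 1 `Nc1ccc(Nc2c(C(=O)NCc3ccc(F)cc3)nc(Br)c3cccnc23)cc1` carries 4-aminophenyl there, and in a functional assay on HCT-116 cells (Homo sapiens) for cytotoxicity, read by MTT assay, with a stated time of 72 h (a lower number here means a stronger inhibitor, a higher number a weaker inhibitor), compound 1 gives 10000 nM. Compound 2 `C[C@@H](Nc1c(C(=O)NCc2ccc(F)cc2)nc(Br)c2cccnc12)c1ccccc1` and compound 3 `C[C@H](Nc1c(C(=O)NCc2ccc(F)cc2)nc(Br)c2cccnc12)c1ccccc1` carry 1-phenylethyl instead, drawn in the two mirror-image forms. For compound 2 this assay reports only a limit, > 20000 nM. For compound 3 this assay likewise reports only a limit, > 20000 nM. Compound 3 therefore stands at the weak end of what has been measured: the step of an at least 2.0-fold higher number from compound 1 to compound 3 (0.30 log units; that floor lies within the scatter) is known only as a floor, and the step that the two limits leave unreadable from compound 2 to compound 3 cannot be read at all, since both values are limits (the limit of > 20000 nM in this assay, at which 2 of the 3 values shown sit).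

Compound 4 `O=C(NCc1ccc(F)cc1)c1nc(Br)c2cccnc2c1NCc1ccc(F)cc1` is compound 3 with the change (4-fluorobenzyl in place of 1-phenylethyl on a nitrogen on an aromatic ring). For the measured compounds named here, the one measured step at this place, an at least 2.0-fold higher number from compound 1 to compound 3 (0.30 log units; that floor lies within the scatter), is itself only a floor, and no measured step shows how 4-fluorobenzyl behaves here. Going by the values given here, nothing among the measured compounds points to a much stronger inhibitor. Compound 4 is therefore expected to show a step of a number no higher from compound 3 to compound 4 (the limit leaves the size open) that stays within the scatter. The estimate for compound 4 is 20000 nM, with a range from 5000 nM to 60000 nM.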

Compound 4, half-maximal inhibitory concentration: > 20000 nM
Compound 4: only a limit was reported; the forecaster's own chance of this, stated with the estimate: 60%; the middle value lies on the limit itself.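

In this assay, a second kind of group on this nitrogen on an aromatic ring now ends at the limit: the limit of > 20000 nM in this assay, at which 3 of the 4 values shown sit. 4-Fluorobenzyl brings a fluorine and drops the one defined stereocentre of 1-phenylethyl, yet the result cannot separate it from 1-phenylethyl: the steps to compound 4 from compound 2 and from compound 3 cannot be read, as each joins two limits. Against the only compound with a true number, the change gives an at least 2.0-fold higher number from compound 1 to compound 4 (0.30 log units; that floor lies within the scatter), so this is a floor and does not show that compound 4 differs from compound 1 by more than the usual scatter.

Still open, from the compounds shown here alone, is how far past the limit compound 2, compound 3 and compound 4 really lie. Also open, going by these compounds, is whether any group at this place can give a stronger inhibitor than compound 1, which gives 10000 nM. A 4-hydroxyphenyl group or a 2-aminoethyl chain on this nitrogen would help show whether the amino group of 4-aminophenyl matters or whether the whole series stays weak here.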